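Replacing piperidin-1-yl with (3-chlorophenyl)amino

The compounds below may be only part of what the source reports. "The series", "measured", "known", "first", "only" and "open" are said of these compounds alone.

Measured in a functional assay on HeLa cells (Homo sapiens) for inhibition, read by sulforhodamine B assay; on this read-out lower numbers stand for stronger inhibition and higher numbers for weaker inhibition:
Compound 1 `O=C1C=C(Nc2ccccc2F)C(=O)c2c1nc1n2[C@H]2OC[C@@H](O)[C@H]2OC1`: 5120 nM
Compound 2 `CCOc1ccc(NC2=CC(=O)c3nc4n(c3C2=O)[C@H]2OC[C@@H](O)[C@H]2OC4)cc1`: 3110 nM
Compound 3 `O=C1C=C(N2CCCCC2)C(=O)c2c1nc1n2[C@H]2OC[C@@H](O)[C@H]2OC1`: > 16000 nM, a limit and not a number

Compound 3 stands at the limit of > 16000 nM in this assay, at which 1 of the 3 values shown sits. The next structure, compound 4 `O=C1C=C(Nc2cccc(Cl)c2)C(=O)c2c1nc1n2[C@H]2OC[C@@H](O)[C@H]2OC1`, differs from it as follows: (3-chlorophenyl)amino in place of piperidin-1-yl on a double-bonded ring carbon. In words, (3-chlorophenyl)amino takes the place of piperidin-1-yl on a double-bonded ring carbon.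

For the measured compounds named here, two measured steps bear on this change. Piperidin-1-yl in place of (2-fluorophenyl)amino gave an at least 3.1-fold higher number from compound 1 to compound 3 (0.49 log units; beyond the scatter). Exchanging one substituted phenyl on the amine nitrogen for another gave a 1.6-fold lower number from compound 1 to compound 2 (0.22 log units; within the scatter). Going back to a substituted phenylamino group is therefore expected to lower the number in this assay. The expected step is an at least 4.0-fold lower number from compound 3 to compound 4 (0.60 log units; beyond the scatter). Compound 4 is estimated at 4000 nM, with an expected range of 1500 nM to 10000 nM.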

Compound 4, half-maximal inhibitory concentration: 6040 nM
For compound 4 the middle estimate is 1.5-fold (0.18 log units) below the measured one; the measured number falls inside the stated range.
By their numbers in this assay, from the lowest: compounds 2, 1 and 4 (each within the scatter of the next). At a limit, above all of these: compound 3.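

In this assay, (3-chlorophenyl)amino in place of piperidin-1-yl gives an at least 2.6-fold lower number from compound 3 to compound 4 (0.42 log units; beyond the scatter). As far as these compounds go, the step starts from a limit and not a number, so its true size is unknown: the limit of > 16000 nM in this assay, at which 1 of the 4 values shown sits. The phenyl groups themselves stay within the scatter, with a 1.2-fold higher number from compound 1 to compound 4 (0.07 log units; within the scatter) and a 1.9-fold higher number from compound 2 to compound 4 (0.29 log units; within the scatter), so changing the substituent on the phenyl ring has shown no clear effect here.

The compounds shown leave open whether the lower number goes with the aromatic ring or with the hydrogen on the amine nitrogen. A cyclohexylamino group or a methyl(phenyl)amino group on the same double-bonded ring carbon would help separate the two.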